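Thiocarbamate with benzyl at the sugar side chain

The source may report more compounds than this note shows. Statements on the series, on what has been measured and on what is new or still open speak of the compounds shown alone.

Three measured compounds share one core and differ only at the oxygen on a saturated carbon. In an assay on DDT1 cells (Cricetulus griseus) for binding affinity to adenosine receptor A1 (Homo sapiens), read by radioligand binding (on this read-out higher numbers stand for weaker inhibition and lower numbers for stronger inhibition), compound 1 `CCCNC(=O)OC[C@H]1OC(n2cnc3c(NC4CCOC4)ncnc32)[C@H](O)[C@@H]1O` gives 235 nM, compound 2 `CCCC/N=C(\S)OC[C@H]1OC(n2cnc3c(NC4CCOC4)ncnc32)[C@H](O)[C@@H]1O` gives 157 nM, and compound 3 `O=C(NC1CCC1)OC[C@H]1OC(n2cnc3c(NC4CCOC4)ncnc32)[C@H](O)[C@@H]1O` gives 306 nM, the highest of the three numbers, though its gaps to the others are small: a 1.3-fold higher number from compound 1 to compound 3 (0.11 log units; within the scatter) and a 1.9-fold higher number from compound 2 to compound 3 (0.29 log units; within the scatter). Compound 4 `O[C@@H]1[C@@H](CO/C(S)=N/Cc2ccccc2)OC(n2cnc3c(NC4CCOC4)ncnc32)[C@@H]1O` is not yet measured; its change from compound 3 is a group of 10 heavy atoms (8 carbon, 1 nitrogen, 1 sulfur; one six-membered aromatic ring of carbon only) in place of a group of 7 heavy atoms (5 carbon, 1 nitrogen, 1 oxygen; one four-membered non-aromatic ring of carbon only), on an oxygen on a saturated carbon. Going by the values given here, two steps bear on it: the exchange of carbamate for thiocarbamate, a 1.5-fold lower number from compound 1 to compound 2 (0.18 log units; within the scatter), and the return to a carbamate with a ring, a 1.9-fold higher number from compound 2 to compound 3 (0.29 log units; within the scatter). Both stayed within the scatter. Because compound 2 gave 157 nM, a slight lean toward a lower number seems plausible. The step is expected to be small, a 1.8-fold lower number from compound 3 to compound 4 (0.26 log units; within the scatter). Compound 4 is estimated at 170 nM, range 70 nM to 420 nM.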

Compound 4, inhibition constant: 12 nM
For compound 4 the middle estimate is 14-fold (1.15 log units) above the measured one; measured number outside the range, below it.
By their numbers in this assay, from the lowest: compound 4; then compounds 2, 1 and 3 (each within the scatter of the next).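

On the oxygen on a saturated carbon, this assay now shows a 13-fold lower number from compound 2 to compound 4 (1.12 log units; beyond the scatter) when phenyl replaces propyl on a saturated chain carbon bound to a double-bonded nitrogen, along with a 20-fold lower number from compound 1 to compound 4 (1.29 log units; beyond the scatter) and a 26-fold lower number from compound 3 to compound 4 (1.41 log units; beyond the scatter) against the two carbamates. The steps among compound 1, compound 2 and compound 3 all stayed within the scatter, so this place can move the number much further than those compounds showed.

A benzyl carbamate would test whether the large step needs the thiocarbamate, and a phenylethyl thiocarbamate would test the chain length before the ring. No measurement here explains the step.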